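Cyclopropyl on the Amide Nitrogen of a Chloro Analogue

The source may report more compounds than this note shows. Statements on the series, on what has been measured and on what is new or still open speak of the compounds shown alone.

Compound 1 `NC(=O)/C=C1\CCc2c(Cl)cccc21` and compound 2 `NC(=O)/C=C1\CCc2ccc(Br)cc21` are built on related cores; the difference between the two cores is not broken down here. In a functional assay on the whole organism with Rattus norvegicus as the target, at a dose of 20 mg/kg by the oral route (a higher number here means more inhibition at the dose given (going by the name of the read-out), a lower number less inhibition), compound 1 gives 35% and compound 2 gives 38%, two numbers that lie within the scatter of each other. Compound 3 `O=C(/C=C1\CCc2ccc(Br)cc21)NC1CC1` differs from compound 2 by cyclopropyl in place of hydrogen on an amide-type nitrogen. In this assay compound 3 gives 29%; the step of a number 9 percentage points lower from compound 2 to compound 3 (within the scatter) stays within the scatter. Compound 4 `O=C(/C=C1\CCc2c(Cl)cccc21)NC1CC1` carries the same change on compound 1, namely (cyclopropyl in place of hydrogen on an amide-type nitrogen). Because the step of a number 9 percentage points lower from compound 2 to compound 3 (within the scatter) stays within the scatter, a similar small step is expected here, a number 7 percentage points lower from compound 1 to compound 4 (within the scatter). Compound 4 is therefore estimated to give about 28%, with an expected range from 12% to 44%.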

Compound 4, a percentage reported as inhibition, in the whole organism at one dose (the size of the read-out at that dose, not a potency): 28%
Compound 4: middle estimate and measured number agree at the digits printed; measured number inside the range.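

In this assay, putting cyclopropyl in place of the amide hydrogen gives this step: a number 7 percentage points lower from compound 1 to compound 4 (within the scatter). Set beside the same change on the other core, it shows that the change carried over between these two cores with no visible difference between the steps: the same change on two cores in this assay, a number 9 percentage points lower (within the scatter) from compound 2 to compound 3 and a number 7 percentage points lower (within the scatter) from compound 1 to compound 4, 2 percentage points apart, within the scatter of two such steps. Since each step stays within the scatter, the pair does not show that cyclopropyl really alters the read-out on either core, and two cores cannot say how a third would respond.

The compounds shown leave open how other groups on this amide nitrogen would behave, such as methyl, a longer chain or a chain ending in an amine. They also leave open whether a core carrying methoxy instead of the halogen would respond alike.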